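A few compounds are considered here, and "the series" means these few. Any claim that something is new, unique, unknown or untested is made for them only; others in the source may bear on it.

Three compounds, all built on a large macrocyclic core, have been measured in a physicochemical assay for lipophilicity, read by HPLC, measured as chromatographic lipophilicity, at pH 7.4; a higher number here means a more lipophilic compound, a lower number a more polar compound. Compound 1 `CCC(=O)NCCCO[C@H]1[C@H](C)[C@@H](O[C@@H]2O[C@H](C)C[C@H](N(C)C)[C@H]2O)[C@](C)(O)C[C@@H](C)CN(C)[C@H](C)[C@@H](O)[C@](C)(O)[C@@H](CC)OC(=O)[C@@H]1C` gives 1.6, and compound 2 `CC[C@H]1OC(=O)[C@H](C)[C@@H](OCCCNC(=O)C2CCC2)[C@H](C)[C@@H](O[C@@H]2O[C@H](C)C[C@H](N(C)C)[C@H]2O)[C@](C)(O)C[C@@H](C)CN(C)[C@H](C)[C@@H](O)[C@]1(C)O` gives 1.78. These two differ in a single place, (ethyl in place of cyclobutyl on a carbonyl carbon), and the resulting step is a number 0.18 log units lower from compound 2 to compound 1 (within the scatter). Compound 3 `CC[C@H]1OC(=O)[C@H](C)[C@@H](O[C@H]2C[C@@](C)(OC)[C@@H](O)[C@H](C)O2)[C@H](C)[C@@H](O[C@@H]2O[C@H](C)C[C@H](N(C)C)[C@H]2OCCCNC(=O)C2CCC2)[C@](C)(O)C[C@@H](C)CN(C)[C@H](C)[C@@H](O)[C@]1(C)O` gives 3.16; its core differs from that of compound 2, but that difference is not broken down here. Compound 4 `CCC(=O)NCCCO[C@H]1[C@H](O[C@@H]2[C@@H](C)[C@H](O[C@H]3C[C@@](C)(OC)[C@@H](O)[C@H](C)O3)[C@@H](C)C(=O)O[C@H](CC)[C@@](C)(O)[C@H](O)[C@@H](C)N(C)C[C@H](C)C[C@@]2(C)O)O[C@H](C)C[C@@H]1N(C)C` has not yet been measured. It carries exactly the same change relative to compound 3 as compound 1 does relative to compound 2, namely (ethyl in place of cyclobutyl on a carbonyl carbon), at the same kind of carbonyl carbon. The step from compound 3 to compound 4 in this assay is therefore expected to be small, about a number 0.18 log units lower from compound 3 to compound 4 (within the scatter), because a number 0.18 log units lower from compound 2 to compound 1 (within the scatter) was itself within the scatter. Compound 4 is thus estimated at 2.98, most likely between 2.6 and 3.35.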

Compound 4, distribution coefficient: 2.7
Beside the measured number, compound 4's estimate is 0.28 log units above it; measured number inside the range.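

In this assay, putting ethyl in place of cyclobutyl on the carbonyl carbon gives a number 0.46 log units lower from compound 3 to compound 4 (beyond the scatter) on this core, while the same change on the other core gives a number 0.18 log units lower from compound 2 to compound 1 (within the scatter) as its result. For the compounds shown here, the direction therefore carries over between these two cores, but only the step on the core of compound 3 lies beyond the scatter, and a single pair on each core cannot establish a general rule for the series. No available evidence explains why the change behaves as it does on either core.

The compounds shown leave open whether the same direction would hold on any further core. They also leave open how a longer chain or an amine on this carbonyl carbon would read in this assay within this series.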